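Amide nitrogen substituent change in the series

A few compounds are considered here, and "the series" means these few. Any claim that something is new, unique, unknown or untested is made for them only; others in the source may bear on it.

In a functional assay on HeLa cells (Homo sapiens) for cytotoxicity, read by MTT assay, with a stated time of 24 h (on this read-out lower numbers stand for stronger inhibition and higher numbers for weaker inhibition), compound 1 `C=CC1=C(C(=O)NCCCCC)C(c2ccc(OC)cc2)OC1` gives only a limit, > 100000 nM. Compound 2 `C=CC1=C(C(=O)Nc2cccc(C)c2)C(c2ccc(F)cc2)OC1` is reported in this assay as "not active" (no number reported), with no number attached. Of the two values shown, one sits at the limit of > 100000 nM in this assay, at which 1 of the 2 values shown sits. Compound 3 `C=CC1=C(C(=O)NC2CCCCC2)C(c2ccc(F)cc2)OC1` differs from compound 2 by cyclohexyl in place of 3-methylphenyl on an amide-type nitrogen. Among the measured compounds shown here, no measured step between compounds is available, so no size for this change can be drawn from the data; the expectation is for no step beyond the scatter, with compound 3 likely to remain without a measurable value in this assay. Compound 3 is estimated at 100000 nM, within 30000 nM to 300000 nM.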

Compound 3, half-maximal inhibitory concentration: > 100000 nM
Compound 3: no number, only a limit; the forecaster's own chance of this, stated with the estimate: 80%; the middle value sits exactly at the limit.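

Among the compounds shown here, compound 2 and compound 3 carry no number, so no step between them can be read. The compounds shown leave open whether any substituent on the amide nitrogen of the shared core gives a measurable cytotoxic value.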